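Benzisoxazole-Free Title: From Benzyl to Pyrimidinylcarbonylamino

This account rests on a few compounds, and the source may have more. Where it says the series, first, only, none or still open, it means among the compounds named here.

Measured compounds:
compound 1, `COC(=O)/C=C/c1ccc2noc(-c3ccccc3)c2c1`, 1580 nM
compound 2, `O=C(O)/C=C/c1ccc2noc(-c3ccc(-c4ccccc4)cc3)c2c1`, 74 nM
compound 3, `O=C(O)c1ccc2noc(-c3ccc(Cc4ccccc4)cc3)c2c1`, 65 nM

In an assay for inhibition of inositol hexakisphosphate kinase 2 (Homo sapiens), read by colorimetric assay, coupled enzyme assay and malachite green, with a stated time of 120 min, in the presence of a further agent that is not named here (a lower number here means a stronger inhibitor, a higher number a weaker inhibitor), compound 3 gives the lowest number of the three, but its gap to compound 2 lies within the scatter, so the two cannot be ordered; only compound 1 stands clearly apart, well beyond the scatter. Compound 4, `O=C(O)c1ccc2noc(-c3ccc(NC(=O)c4ccncn4)cc3)c2c1`, differs from compound 3 in one place: ((pyrimidin-4-yl)carbonyl)amino in place of benzyl on an aromatic carbon. Among the compounds with values here, no measured pair shows this kind of change, so its effect is unknown. A step of moderate size toward a higher number is expected, because the starting point is compound 3 at 65 nM and the new group is unlike anything measured; the estimated step is a 2.3-fold higher number from compound 3 to compound 4 (0.36 log units; beyond the scatter). Compound 4 is therefore expected to give about 150 nM, between 30 nM and 800 nM.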

Compound 4, half-maximal inhibitory concentration: 720 nM
The estimate for compound 4 lay 4.8-fold (0.68 log units) below the measured number; the measured number falls inside the stated range.
By their numbers in this assay, from the lowest: compounds 3 and 2 (each within the scatter of the next); then compound 4; then compound 1.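

In this assay, ((pyrimidin-4-yl)carbonyl)amino in place of benzyl on this aromatic carbon, para to a large group, gives an 11-fold higher number from compound 3 to compound 4 (1.04 log units; beyond the scatter). Within the data shown here, this is the first one-place change, and it shows that the position does not treat these two groups alike. Nothing available explains the difference.

The compounds shown do not separate the contribution of the carbonylamino link from that of the pyrimidine ring. A benzoylamino group, which keeps the link but carries a plain benzene ring, would tell these two apart.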